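Thiophene in Place of Chlorophenyl on a Sulfonyl Group

The source may report more compounds than this note shows. Statements on the series, on what has been measured and on what is new or still open speak of the compounds shown alone.

Measured so far:
- compound 1 `CN1CCN(c2ccc3[nH]nc(S(=O)(=O)c4ccccc4Cl)c3c2)CC1`: 4 nM
- compound 2 `COc1ccc(S(=O)(=O)c2n[nH]c3cc(N4CCNCC4)ccc23)cc1`: 124 nM
- compound 3 `O=S(=O)(c1ccc(Cl)cc1)c1n[nH]c2cccc(N3CCNCC3)c12`: 125 nM

These numbers come from an assay on HeLa cells for displacement of a labelled ligand from 5-hydroxytryptamine receptor 6 (Homo sapiens); a lower number here means a stronger inhibitor, a higher number a weaker inhibitor. Compound 1 gives the lowest number of the three; compound 2 and compound 3 each give a far higher number, beyond the scatter, so compound 1 is the strongest binder of the measured set. Compound 4 `CN1CCN(c2ccc3[nH]nc(S(=O)(=O)c4cccs4)c3c2)CC1` has not yet been measured. It differs from compound 1 in one place: thiophen-2-yl in place of 2-chlorophenyl on a sulfonyl sulfur. Going by the values given here, no measured pair shows this exact change, so the size of the step is uncertain. For compound 4 a modest weakening is expected in this assay, a 2.5-fold higher number from compound 1 to compound 4 (0.40 log units; beyond the scatter), a step near the edge of the scatter. The estimate for compound 4 is 10 nM, with a range from 3 nM to 40 nM.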

Compound 4, inhibition constant: 7.8 nM
For compound 4 the middle estimate is 1.3-fold (0.11 log units) above the measured one; the measured number falls inside the stated range.
By their numbers in this assay, from the lowest: compounds 1 and 4 (each within the scatter of the next); then compounds 2 and 3 (each within the scatter of the next).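

On the sulfonyl sulfur, thiophen-2-yl in place of 2-chlorophenyl gives a 2.0-fold higher number from compound 1 to compound 4 (0.29 log units; within the scatter) in this assay, so this assay does not separate the two groups. At this position, a five-membered aromatic ring with a sulfur atom and a chlorine-bearing six-membered aromatic ring of carbon only therefore sit within the scatter of each other. No measurement here explains this result.

The compounds shown leave open whether a non-aromatic group such as cyclohexyl or a short chain such as methyl on the sulfonyl sulfur would fall in the same range. Plain phenyl at this position would also show whether the chlorine matters.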